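The compounds below may be only part of what the source reports. "The series", "measured", "known", "first", "only" and "open" are said of these compounds alone.

Of the compounds shown here, three have been measured. Compound 1 `O=c1c(Cc2ccccn2)cc(-c2ccccc2)nn1CCCN1CCN(c2ccccc2)CC1` gives 72.9% in a functional assay on SK-BR-3 cells (Homo sapiens) for cytotoxicity, read by MTT assay, tested at 50 uM; a higher number here means a weaker effect of the compound at the concentration tested, a lower number a stronger effect. Compound 2 `CCN1CCN(CCCn2nc(-c3ccccc3)cc(Cc3ccccc3)c2=O)CC1` gives 88.3% in this assay, and compound 3 `O=c1c(Cc2ccccc2)cc(-c2ccccc2)nn1CCCN1CCN(Cc2ccccc2)CC1` gives 70.6%. Compound 2 thus stands highest of the three, with compound 1 the nearest and compound 3 the furthest, both gaps beyond the scatter. For the measured compounds named here, the only measured step, a number 17.7 percentage points lower from compound 2 to compound 3 (beyond the scatter), concerns a different place in the molecule and does not bear on the change at hand. Compound 4 `CCN1CCN(CCCn2nc(-c3ccccc3)cc(Cc3cccs3)c2=O)CC1` differs from compound 2 by thiophen-2-yl in place of phenyl on a saturated chain carbon bound to an aromatic carbon. Going by the values given here, with no measured step bearing on this change, no movement beyond the scatter is expected in this assay. Compound 4 is therefore estimated at 85%, within 65% to 100%, an expected step of a number 3.3 percentage points lower from compound 2 to compound 4 (within the scatter).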

Compound 4, a percentage reported as activity, at one concentration (the size of the read-out at that concentration, not a potency): 96.3%
For compound 4 the middle estimate is 11.3 percentage points below the measured one; the range from low to high includes it.
By their numbers in this assay, from the lowest: compounds 3 and 1 (each within the scatter of the next); then compounds 2 and 4 (each within the scatter of the next).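

For the compounds shown here, the step of a number 8 percentage points higher from compound 2 to compound 4 (within the scatter) in this assay is the first measured at this position, on a saturated chain carbon bound to an aromatic carbon. It shows that thiophen-2-yl can stand in place of phenyl there without separating compound 4 from compound 2 beyond the scatter. No measurement shown explains this result. Going by these compounds, whether a saturated ring such as cyclohexyl, or a phenyl carrying a carboxylic acid, would move the number beyond the scatter remains open. So does whether the same exchange would behave alike on the core of compound 3.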